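The source may hold more compounds than are shown below. What is called first, only, known or untested is meant among the compounds shown, and "the series" means these compounds.

In an assay on isolated protein for inhibition of protein kinase C theta type (Homo sapiens), read by TR-FRET, with a stated time of 2 h (a lower number here means a stronger inhibitor, a higher number a weaker inhibitor), compound 2 `CC1(C)[C@@H](C(N)=O)C[C@H]1Nc1cc(NCc2cnccc2C(F)(F)F)ncc1C#N` gives 1.4 nM, the lowest of the two numbers measured; compound 1 `N#Cc1cnc(NCc2cnccc2C(F)(F)F)cc1N[C@H]1CC[C@@H](O)CC1` gives 100 nM, and the step of a 71-fold lower number from compound 1 to compound 2 (1.85 log units; beyond the scatter) is large. Compound 3 `CC1(C)[C@@H](Nc2cc(NCc3cnccc3C(F)(F)F)ncc2C#N)C[C@@H]1C(N)=O` differs from compound 2 only in that (the two compounds have the same atoms and bonds and differ only in configuration as drawn: 1 of 2 stereo elements differ; a stereocentre at a saturated ring carbon is drawn R in compound 2 and S in compound 3). Among the measured compounds shown here, the single measured step concerns a swap of one ring group for another, not a change of configuration, so no measured step bears directly on this change. For compound 3 a modestly higher number is expected, a step of a 4.3-fold higher number from compound 2 to compound 3 (0.63 log units; beyond the scatter), giving an estimate of 6 nM within a range of 1 nM to 60 nM.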

Compound 3, half-maximal inhibitory concentration: 1100 nM
For compound 3 the middle estimate is 180-fold (2.26 log units) below the measured one; measured number above the stated range.
By their numbers in this assay, from the lowest: compound 2; then compound 1; then compound 3.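

In this assay, changing one stereocentre at a saturated ring carbon, with the atoms and bonds untouched, gives a 790-fold higher number from compound 2 to compound 3 (2.90 log units; beyond the scatter). The 3-carbamoyl-2,2-dimethylcyclobutyl group therefore brings no gain over 4-hydroxycyclohexyl by itself: drawn the other way, it gives an 11-fold higher number from compound 1 to compound 3 (1.04 log units; beyond the scatter), the opposite direction to a 71-fold lower number from compound 1 to compound 2 (1.85 log units; beyond the scatter). This whole loss can be assigned to that one stereocentre because nothing else separates the pair: the fact that compounds 2 and 3 differ only in the configuration as drawn

Still open, from the compounds shown here alone, is how much the second stereocentre matters. Also open, going by these compounds, is whether a carboxylic acid or an amine in place of the carbamoyl group would keep the number as low as in compound 2.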